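Replacing the 4-chlorophenyl group of compound 3

The compounds below may be only part of what the source reports. "The series", "measured", "known", "first", "only" and "open" are said of these compounds alone.

How long a compound survives in liver preparations is a basic early check, and here it is read in an ADME assay (liver, Mus musculus) for metabolic stability, using microsomes (on this read-out higher numbers stand for a longer-lived compound and lower numbers for a shorter-lived compound), for a small series. Compound 1 `Cc1nc2ccc(Cl)cn2c1C(=O)NCc1ccc(-c2ccccc2)cc1` gives > 1 h as a limit, not a number. Compound 2 `CCc1nc2ccc(Cl)cn2c1C(=O)NCc1ccc(-c2ccc(C#N)cc2)cc1` gives > 1 h as a limit too. Compound 3 `CCc1nc2cc(Cl)ccn2c1C(=O)NCc1ccc(-c2ccc(Cl)cc2)cc1` gives > 1 h and this is also a limit. Compound 3 therefore stands at the limit of > 1 h in this assay, at which 3 of the 3 values shown sit, and no order among the three can be read.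

Compound 4 `CCc1nc2cc(Cl)ccn2c1C(=O)NCc1ccc(N2CCN(C(C)C)CC2)cc1` carries 4-isopropylpiperazin-1-yl in place of the 4-chlorophenyl of compound 3, on an aromatic carbon, para to a large group. The count 4-isopropylpiperazin-1-yl in place of 4-chlorophenyl on an aromatic carbon gives the full difference. Within the data shown here, no measured pair shows what such a swap does, so any expectation here is loose. A modest shortening is expected, estimated as an at least 1.4-fold lower number from compound 3 to compound 4 (0.15 log units; that floor lies within the scatter) and to be read with caution. For compound 4 the estimated half-life is 0.7 h with an expected range from 0.2 h to 2 h in this assay once it is measured.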

Compound 4, half-life: 0.148 h
Compound 4: middle estimate off by 4.7-fold (0.67 log units), on the high side; the measured number lies below the stated range.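

The 4-chlorophenyl position, on an aromatic carbon and para to a large group, turns out to matter for survival in this assay: with 4-isopropylpiperazin-1-yl in place of 4-chlorophenyl, the read-out shows an at least 6.7-fold lower number from compound 3 to compound 4 (0.82 log units; beyond the scatter). The earlier compounds shown here could not show this, as they all stopped at the same limit and offered no difference to read. The step gives only a minimum and not an exact size because compound 3 has a limit rather than a number: the limit of > 1 h in this assay, at which 3 of the 4 values shown sit.

From the compounds shown here alone, the swap changes a whole group at once, so it remains open whether the drop follows the piperazine ring or its isopropyl. A morpholine ring at this place, or a piperazine carrying a methyl or an acetyl instead of the isopropyl, could begin to separate the two.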